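The source may report more compounds than this note shows. Statements on the series, on what has been measured and on what is new or still open speak of the compounds shown alone.

Measured so far in an ADME assay on the whole organism (Rattus norvegicus, strain Sprague-Dawley) for pharmacokinetics, read by LC-MS, with a stated time of 72 h, at a dose of 1 mg/kg by the intravenous route (on this read-out higher numbers stand for higher exposure at the dose given and lower numbers for lower exposure), for two compounds on the shared core:
compound 1 `CN1CC[C@H](N(c2cc(C#CC(C)(C)C)sc2C(=O)O)C(=O)[C@H]2CC[C@H](C)CC2)C1=O` gives 229 ng.h/mL on this read-out
compound 2 `CN1CCCC[C@@H](N(c2cc(C#CC(C)(C)C)sc2C(=O)O)C(=O)[C@H]2CC[C@H](C)CC2)C1=O` gives 1130 ng.h/mL on this read-out

Compound 2 holds the higher of the two numbers. Compound 3 `CN1CCCC[C@H](N(c2cc(C#CC(C)(C)C)sc2C(=O)O)C(=O)[C@H]2CC[C@H](C)CC2)C1=O` differs from compound 2 in configuration alone: the two compounds have the same atoms and bonds and differ only in configuration as drawn: 2 of 3 stereo elements differ; a stereocentre at a saturated ring carbon is drawn R in compound 2 and S in compound 3; a stereocentre at a saturated ring carbon is drawn R in compound 2 and S in compound 3 and no group leaves or enters. Among the compounds with values here, the only measured step is a 4.9-fold higher number from compound 1 to compound 2 (0.69 log units; beyond the scatter) and it concerns ring size, not configuration, so it bears on this change only loosely. Within the data shown here, no measured pair isolates configuration. As far as these compounds go, the size of that step in this assay is taken as a rough outer bound, and the direction stays open, with a slight lean downward from the top position of compound 2. For compound 3 the expected value is 700 ng.h/mL with an estimated range from 200 ng.h/mL to 2500 ng.h/mL as the likely span. This estimate means a 1.6-fold lower number from compound 2 to compound 3 (0.21 log units; within the scatter) as the expected step.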

Compound 3, area under the concentration-time curve: 1480 ng.h/mL
Compound 3: middle estimate off by 2.1-fold (0.33 log units), on the low side, within the range that was stated.
By their numbers in this assay, from the lowest: compound 1; then compounds 2 and 3 (each within the scatter of the next).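

In this assay, the change of configuration gives a 1.3-fold higher number from compound 2 to compound 3 (0.12 log units; within the scatter), so on this read-out the drawn configuration does not separate the two compounds carrying 1-methyl-2-oxoazepan-3-yl: the fact that compounds 2 and 3 differ only in the configuration as drawn

The gain from 1-methyl-2-oxoazepan-3-yl in place of 1-methyl-2-oxopyrrolidin-3-yl on the amide-type nitrogen now appears in both drawn forms, as a 4.9-fold higher number from compound 1 to compound 2 (0.69 log units; beyond the scatter) and as a 6.5-fold higher number from compound 1 to compound 3 (0.81 log units; beyond the scatter). Within the data shown here, the ring change at this position therefore no longer rests on a single configuration, although compound 1 remains the only example of the smaller ring.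

Open, as far as these compounds go, is whether configuration matters any more for the 1-methyl-2-oxopyrrolidin-3-yl compound than it does for compounds 2 and 3. Also open, from the compounds shown here alone, is where a 1-methyl-2-oxopiperidin-3-yl group would fall relative to these compounds.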